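The source may report more compounds than this note shows. Statements on the series, on what has been measured and on what is new or still open speak of the compounds shown alone.

For the measured compounds named here, compound 2 `COc1ccc(NC(=O)Nc2ccc3ncnc(Nc4cccc(C(F)(F)F)c4)c3c2)cc1` carries a methoxy group on its outer phenyl ring; in a functional assay on A549 cells (Homo sapiens) for antiproliferative activity, read by MTT assay, with a stated time of 72 h (on this read-out lower numbers stand for stronger inhibition and higher numbers for weaker inhibition), compound 2 gives 9470 nM, the highest of the two numbers measured so far. Its nearest relative is compound 1 `CCN(CC)Cc1ccc(NC(=O)Nc2ccc3ncnc(Nc4cccc(C(F)(F)F)c4)c3c2)cc1`, which in this assay gives 2070 nM. The two differ only by methoxy in place of (diethylamino)methyl, and that step read a 4.6-fold higher number from compound 1 to compound 2 (0.66 log units; beyond the scatter).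

Compound 3 `CCN(CC)c1ccc(NC(=O)Nc2ccc3ncnc(Nc4cccc(C(F)(F)F)c4)c3c2)cc1` has not yet been measured. It differs from compound 2 by diethylamino in place of methoxy on an aromatic carbon. Going by the values given here, the one measured step that bears on this change is the one from compound 1 to compound 2, where exchanging (diethylamino)methyl for methoxy raised the number beyond the scatter; compound 3 reintroduces a diethylamino nitrogen on that ring, now directly attached and without the methylene that compound 1 has. The two diethylamino-bearing groups are not identical, and the size of the step is less certain than its direction. A move back toward the value of compound 1 is expected. Compound 3 is expected to give about 3000 nM, within a range of 1000 nM to 9000 nM, which corresponds to an expected step of a 3.2-fold lower number from compound 2 to compound 3 (0.50 log units; beyond the scatter).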

Compound 3, half-maximal inhibitory concentration: 3520 nM
Compound 3: the middle estimate sits 1.2-fold (0.07 log units) below what was measured; the measured number falls inside the stated range.
By their numbers in this assay, from the lowest: compounds 1 and 3 (each within the scatter of the next); then compound 2.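

In this assay, diethylamino in place of methoxy on this aromatic carbon, para to a large group, gives a 2.7-fold lower number from compound 2 to compound 3 (0.43 log units; beyond the scatter), so a diethylamino nitrogen directly on the ring also stands apart from methoxy, as the (diethylamino)methyl group of compound 1 already did. The methylene of compound 1 is not needed at this position for that separation, since a 1.7-fold higher number from compound 1 to compound 3 (0.23 log units; within the scatter) leaves compound 1 and compound 3 indistinguishable in this read-out. Across these three compounds, both diethylamino-bearing groups separate from methoxy and none goes against that pattern, while no supporting data are available to explain it.

The compounds shown do not separate the contribution of the nitrogen from that of the two ethyl chains; a dimethylamino group, a morpholine ring or a plain butyl chain on the same carbon would bear on that question. Going by these compounds, the trifluoromethyl group, the urea and the shared core are constant throughout, so it remains open whether the diethylamino and (diethylamino)methyl groups would read the same way with any of these changed.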